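The compounds below may be only part of what the source reports. "The series", "measured", "known", "first", "only" and "open" are said of these compounds alone.

Three compounds share one core and differ only in the group carried on an amine nitrogen in a ring. In a functional assay on CHO-K1 cells for agonist activity at Glucose-dependent insulinotropic receptor (Homo sapiens), read by a luciferase reporter, with a stated time of 5 h (a higher number here means that more compound is needed for the effect, a lower number that less compound is needed), compound 1 `CC(C)c1noc(N2CCC(Oc3ncnc4c3CCN4c3ccc(S(C)(=O)=O)cc3F)CC2)n1` gives 79.4 nM, compound 2 `Cc1nc(OC2CCN(C(=O)OC(C)(C)C)CC2)c2c(n1)N(c1ccc(S(C)(=O)=O)cc1F)CC2` gives 126 nM, and compound 3 `Cc1nc(OC2CCN(C(=O)OC(C)C)CC2)c2c(n1)N(c1ccc(S(C)(=O)=O)cc1F)CC2` gives 100 nM. Among the measured compounds shown here, the only measured step among them, from compound 2 to compound 3, is a 1.3-fold lower number from compound 2 to compound 3 (0.10 log units; within the scatter), so trimming the tert-butyl group to isopropyl changed nothing that the assay can resolve. Compound 3 thus sits between the other two, and all three numbers lie within the scatter of one another.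

Compound 4 `Cc1nc(OC2CCN(c3nc(C(C)C)no3)CC2)c2c(n1)N(c1ccc(S(C)(=O)=O)cc1F)CC2` carries the change (3-isopropyl-1,2,4-oxadiazol-5-yl in place of isopropoxycarbonyl on an amine nitrogen in a ring). For the measured compounds named here, no measured step covers this exact exchange. What bears on it is compound 1, which already carries the 3-isopropyl-1,2,4-oxadiazol-5-yl group on the same ring nitrogen, though on a core lacking the methyl of compounds 2 and 3. In this assay compound 1 gives 79.4 nM. This number is close to that of compound 3. The expectation is therefore a step of a 1.3-fold lower number from compound 3 to compound 4 (0.10 log units; within the scatter), with no change beyond the scatter. Compound 4 is estimated at 80 nM in this assay, within a range from 40 nM to 160 nM.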

Compound 4, half-maximal effective concentration: 251 nM
Estimate against measurement, compound 4: 3.1-fold (0.50 log units) below; the whole stated range lies below it.
By their numbers in this assay, from the lowest: compounds 1, 3, 2 and 4 (each within the scatter of the next, the first and the last beyond it).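

In this assay, among the compounds shown here, putting 3-isopropyl-1,2,4-oxadiazol-5-yl in place of isopropoxycarbonyl on the amine nitrogen in the ring gives a 2.5-fold higher number from compound 3 to compound 4 (0.40 log units; beyond the scatter), a modest step but the first change on this nitrogen that the assay can resolve. Against tert-butoxycarbonyl, the same group gives a 2.0-fold higher number from compound 2 to compound 4 (0.30 log units; within the scatter), so this exchange stays within the scatter and only the step from isopropoxycarbonyl is resolved. For the compounds shown here, with the 3-isopropyl-1,2,4-oxadiazol-5-yl group held fixed, adding a methyl on an aromatic carbon gives a 3.2-fold higher number from compound 1 to compound 4 (0.50 log units; beyond the scatter), a modest step that the earlier compounds could not isolate, and it shows that the number for this group on the core of compound 1 does not carry over unchanged to the methyl-bearing core.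

Nothing available here explains why either resolved step points towards a higher number. Still open, as far as these compounds go, is whether the methyl gives a step of similar size when isopropoxycarbonyl sits on the nitrogen, and how a different group there, such as acetyl or benzyl, would compare.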